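Swapping the side chain on a benzyl ester

The source may report more compounds than this note shows. Statements on the series, on what has been measured and on what is new or still open speak of the compounds shown alone.

Measured so far:
Compound 1, `O=C(O)[C@@H]1CCCN1C(=O)CN(c1nc(Cl)nc2[nH]cnc12)C1CC1`: 7.29%
Compound 2, `N=C(N)NCCC[C@H](NC(=O)CN(c1nc(Cl)nc2[nH]cnc12)C1CC1)C(=O)OCc1ccccc1`: 6.12%
Compound 3, `O=C(OCc1ccccc1)[C@@H]1CCCN1C(=O)CN(c1nc(Cl)nc2[nH]cnc12)C1CC1`: 31.1%

In a functional assay on the whole organism (Tail, strain ICR) with Mus musculus as the target, in the tail flick test, with a stated time of 150 min, at a dose of 25 umol/kg by the oral route (a lower number here means a weaker effect, a higher number a stronger effect of the compound at the dose given), compound 2 gives the lowest of the three numbers; its gap to compound 1 lies within the scatter, while compound 3 stands beyond the scatter above it. Compound 4, `CC[C@H](C)[C@H](NC(=O)CN(c1nc(Cl)nc2[nH]cnc12)C1CC1)C(=O)OCc1ccccc1`, differs from compound 2 in one place: a group of 4 heavy atoms (4 carbon; no ring) in place of a group of 7 heavy atoms (4 carbon, 3 nitrogen; no ring), on a saturated chain carbon bound to an amide-type nitrogen and a carbonyl carbon. Among the measured compounds shown here, no measured step changes this position, so none bears on it directly. For the measured compounds named here, the only step known, a number 23.8 percentage points higher from compound 1 to compound 3 (beyond the scatter), concerns the ester oxygen, which compound 2 and compound 4 share. Whether the new side chain moves the number is therefore open, and a wide range is needed. Compound 4 is expected to give 18% (range 3% to 38%), an estimated step of a number 11.9 percentage points higher from compound 2 to compound 4 (beyond the scatter).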

Compound 4, a percentage reported as activity, at one dose (the size of the read-out at that dose, not a potency): 6.9%
Compound 4: the middle estimate sits 11.1 percentage points above what was measured; the measured number falls inside the stated range.
By their numbers in this assay, from the lowest: compounds 2, 4 and 1 (each within the scatter of the next); then compound 3.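

In this assay, sec-butyl in place of the longer nitrogen-bearing side chain gives a number 0.8 percentage points higher from compound 2 to compound 4 (within the scatter), so this swap leaves the read-out unmoved. On a saturated chain carbon bound to an amide-type nitrogen and a carbonyl carbon, a group with 0 hydrogen-bond donors reads the same as one with 3. Nothing available explains why the two side chains read alike.

As far as these compounds go, whether a carboxylic acid, an amine or a longer carbon chain at this place would read differently remains open. So does whether the opposite arrangement at the sec-butyl stereocentre would read the same.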